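A triazole-linked phenyl on a perfluorinated hydroxamate

The source may hold more compounds than are shown below. What is called first, only, known or untested is meant among the compounds shown, and "the series" means these compounds.

Compound 3 `O=C(NO)C(F)(F)C(F)(F)C(F)(F)C(F)(F)C(F)(F)C(F)(F)C(=O)Nc1cccc(-c2ccccc2)c1` carries a perfluorinated chain between a hydroxamic acid and an amide whose nitrogen bears a 3-phenylphenyl group. In an ADME assay on isolated protein for inhibition of histone deacetylase 4 (Homo sapiens), read by fluorescence, with stated times of 30 min and 60 min (on this read-out lower numbers stand for stronger inhibition and higher numbers for weaker inhibition), compound 3 gives > 50000 nM, which is a limit of the assay and not a number. Compound 1 `Cc1cccc(NC(=O)C(F)(F)C(F)(F)C(F)(F)C(F)(F)C(F)(F)C(F)(F)C(=O)NO)c1` gives > 50000 nM in this assay, again only a limit. Compound 2 `CC(=O)Nc1ccc(NC(=O)C(F)(F)C(F)(F)C(F)(F)C(F)(F)C(F)(F)C(F)(F)C(=O)NO)cc1` gives > 50000 nM in this assay, also a limit. Because all three measured compounds sit together (the limit of > 50000 nM in this assay, at which 3 of the 3 values shown sit), the steps among them cannot be read: a step that the two limits leave unreadable from compound 1 to compound 2, a step that the two limits leave unreadable from compound 1 to compound 3 and a step that the two limits leave unreadable from compound 2 to compound 3. Compound 3 thus stands with the other two, and nothing in the numbers shown separates it from them.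

Compound 4 `O=C(NO)C(F)(F)C(F)(F)C(F)(F)C(F)(F)C(F)(F)C(F)(F)C(=O)Nc1cccc(-c2cn(-c3ccccc3)nn2)c1` differs from compound 3 in one place: 1-phenyl-1H-1,2,3-triazol-4-yl in place of phenyl on an aromatic carbon. For the measured compounds named here, no measured step bears on this change in a readable way, since every step among compounds 1, 2 and 3 is hidden by the limit; exchanging 3-methylphenyl for 4-acetamidophenyl or 3-phenylphenyl on the amide-type nitrogen left all three there. The account therefore expects compound 4 to remain unresolved as well, with the step that the limit leaves unreadable from compound 3 to compound 4 most likely not readable either. Compound 4 is estimated to give 60000 nM in this assay, with a range from 20000 nM to 200000 nM.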

Compound 4, inhibition constant: > 50000 nM
Compound 4 ended at the assay's limit (the forecaster's own chance of this, stated with the estimate: 85%); the middle value does not contradict the limit.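

In this assay compound 4 gives > 50000 nM, again a limit of the assay and not a number. Neither the step from compound 3 to compound 4 nor the step from compound 1 to compound 4 can be read: the limit of > 50000 nM in this assay, at which 4 of the 4 values shown sit. The compounds shown leave open whether any group on the amide-type nitrogen would give a measurable inhibition constant in this assay.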